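The source may hold more compounds than are shown below. What is called first, only, known or untested is meant among the compounds shown, and "the series" means these compounds.

Measured to date:
- compound 1, `OC[C@H]1O[C@@H](n2cnc3c(NCc4cccc(F)c4)ncnc32)[C@H](O)[C@@H]1O`: 7600 nM
- compound 2, `COc1cccc(CNc2ncnc3c2ncn3[C@@H]2O[C@H](CO)[C@@H](O)[C@H]2O)c1O`: 27900 nM

Both were run in a functional assay on K562 cells (Homo sapiens) for antiproliferative activity, with a stated time of 72 h; on this read-out lower numbers stand for stronger inhibition and higher numbers for weaker inhibition. Compound 2 stands at the highest of the two numbers recorded; its nearest neighbour is compound 1, and the step between them was a 3.7-fold higher number from compound 1 to compound 2 (0.56 log units; beyond the scatter).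

Compound 3, `OC[C@H]1O[C@@H](n2cnc3c(NCc4ccc(C(F)(F)F)cc4)ncnc32)[C@H](O)[C@@H]1O`, has not yet been run in this assay. It differs from compound 2 in one place: 4-(trifluoromethyl)phenyl in place of 2-hydroxy-3-methoxyphenyl on a saturated chain carbon bound to a nitrogen on an aromatic ring.

Among the compounds with values here, only one measured step bears on this change, the one from compound 1 to compound 2, which was beyond the scatter and pointed toward a higher number when the 2-hydroxy-3-methoxyphenyl group entered. Compound 3 removes that group again and brings in 4-(trifluoromethyl)phenyl, which, like the 3-fluorophenyl of compound 1, carries no hydrogen-bond donor or acceptor. Within the data shown here, the expectation is therefore a step back toward the number of compound 1, estimated as a 3.1-fold lower number from compound 2 to compound 3 (0.49 log units; beyond the scatter), with real uncertainty since no trifluoromethyl analogue has been measured. For compound 3 the estimated value in this assay is 9000 nM, within a range of 3000 nM to 27000 nM.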

Compound 3, half-maximal inhibitory concentration: > 166000 nM
Compound 3: a limit, no number; the forecaster's own chance of this, stated with the estimate: 10%; at least 18-fold (1.26 log units) between middle value and limit.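

In this assay compound 3 gives a limit and not a number: the limit of > 166000 nM in this assay, at which 1 of the 3 values shown sits. Within the data shown here, the change to 4-(trifluoromethyl)phenyl on a saturated chain carbon bound to a nitrogen on an aromatic ring gives an at least 5.9-fold higher number from compound 2 to compound 3 (0.77 log units; beyond the scatter) and, against the 3-fluorophenyl analogue, an at least 21-fold higher number from compound 1 to compound 3 (1.33 log units; beyond the scatter), so the aryl group at this place can shift the read-out much further than the single earlier step indicated. The absence of hydrogen-bond donors and acceptors from the entering group therefore does not by itself keep a compound close to compound 1, and compound 2, whose group carries both, stands closer to compound 1 than compound 3 does.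

Going by these compounds, the true size of both new steps remains unknown, as only their lower bounds can be read from a limit. The compounds shown also do not separate the effect of the trifluoromethyl group from that of its placement on the ring, a question that 4-fluorophenyl and 3-(trifluoromethyl)phenyl on the same carbon would address, and they leave open how an aryl group bearing an amine or a carboxylic acid would behave here.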